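The source may hold more compounds than are shown below. What is called first, only, known or untested is meant among the compounds shown, and "the series" means these compounds.

Measured compounds:
Compound 1 `COc1cccc(Sc2c(/C=C/[C@@H]3C[C@@H](O)CC(=O)O3)cnc3cc(Cl)c(F)cc23)c1`, in an assay (strain Holtzman-Sprague-Dawley) for inhibition of 3-hydroxy-3-methylglutaryl-coenzyme A reductase (Rattus norvegicus), with a stated time of 30 min (on this read-out higher numbers stand for weaker inhibition and lower numbers for stronger inhibition), compound 1 gives 9240 nM.
Compound 2 `COc1cccc(Sc2c(F)cc3c(Sc4cccc(OC)c4)c(/C=C/[C@@H]4C[C@@H](O)CC(=O)O4)cnc3c2Sc2cccc(OC)c2)c1`, in this assay compound 2 gives 74600 nM.

Of the two numbers, compound 1 holds the lower one, and its gap to compound 2 lies beyond the scatter. Compound 3 `CC(C)c1ccc(Sc2c(/C=C/[C@@H]3C[C@@H](O)CC(=O)O3)cnc3cc(Cl)c(F)cc23)cc1` is not yet measured; it differs from compound 1 by 4-isopropylphenyl in place of 3-methoxyphenyl on a sulfur. Among the measured compounds shown here, no step between measured compounds bears on this change, so the direction is open. The expected step from compound 1 to compound 3 in this assay is small, a 1.3-fold lower number from compound 1 to compound 3 (0.12 log units; within the scatter), close to the scatter. Compound 3 is estimated at 7000 nM, with a range of 1500 nM to 30000 nM.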

Compound 3, half-maximal inhibitory concentration: 22100 nM
Compound 3: the middle estimate sits 3.2-fold (0.50 log units) below what was measured; the range from low to high includes it.
By their numbers in this assay, from the lowest: compound 1; then compound 3; then compound 2.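

In this assay, among the compounds shown here, the group on the sulfur can move the number: 4-isopropylphenyl in place of 3-methoxyphenyl gives a 2.4-fold higher number from compound 1 to compound 3 (0.38 log units; beyond the scatter) and is the first step read at this position. This single exchange alters both the substituent and its place on the ring, and the two effects stay unseparated. Nothing available accounts for the step. From the compounds shown here alone, whether 4-methoxyphenyl or 3-isopropylphenyl on the sulfur would separate them stays open, as does how 4-aminophenyl there would compare with compound 1.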